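Swapping the sulfur-linked aryl group in an acrylamide series

This account rests on a few compounds, and the source may have more. Where it says the series, first, only, none or still open, it means among the compounds named here.

Measured compounds:
Compound 1 `Nc1ccccc1NC(=O)c1ccc(CSc2ccc(Br)cc2)cc1` gives 6.17% in a functional assay on A-375 cells (Homo sapiens) for inhibition, read by CCK-8 assay, with a stated time of 72 h, tested at 8 uM; on this read-out higher numbers stand for more inhibition of growth at the one concentration tested and lower numbers for less inhibition of growth.
Compound 2 `Nc1ccccc1NC(=O)/C=C/c1ccc(CSc2ccc(Cl)cc2)cc1` gives 48.2% in this assay.
Compound 3 `COc1ccc(SCc2ccc(C(=O)Nc3ccccc3N)cc2)cc1` gives 81.8% in this assay.

Compound 2 stands second of the three numbers: below compound 3, which is higher by more than the scatter, and above compound 1, which is lower by more than the scatter. The new compound 4 `Nc1ccccc1NC(=O)/C=C/c1ccc(CSc2ccc(C(F)(F)F)cn2)cc1` differs from compound 2 in one place: 5-(trifluoromethyl)pyridin-2-yl in place of 4-chlorophenyl on a sulfur.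

For the measured compounds named here, only one measured step exists, a number 75.6 percentage points higher from compound 1 to compound 3 (beyond the scatter), and it concerns the same position, the aryl group carried by the sulfur, but in a core without the double bond of compound 2, and it exchanges one substituent rather than the whole ring. It shows that a change at this position can move the number a long way, yet it gives no direction for a 5-(trifluoromethyl)pyridin-2-yl in place of 4-chlorophenyl. The step of a number 3.2 percentage points lower from compound 2 to compound 4 (within the scatter) is therefore expected to be small, with wide uncertainty in either direction. Compound 4 is estimated at 45%, between 15% and 75%.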

Compound 4, percent growth inhibition at one concentration: 3.96%
Estimate against measurement, compound 4: 41 percentage points above, outside the stated range (below it).
By their numbers in this assay, from the lowest: compounds 4 and 1 (each within the scatter of the next); then compound 2; then compound 3.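

The step of a number 44.2 percentage points lower from compound 2 to compound 4 (beyond the scatter) in this assay shows that the aryl group on the sulfur also matters strongly in the core with the double bond, not only in the core of compound 1, where the step was a number 75.6 percentage points higher from compound 1 to compound 3 (beyond the scatter). This change replaces a ring carbon with a ring nitrogen and chlorine with trifluoromethyl at once, and a single step cannot show how much of the loss belongs to each. Nothing measured here explains the drop.

Open, from the compounds shown here alone, is whether a phenyl ring carrying trifluoromethyl, or a pyridin-2-yl ring carrying chlorine, would keep the number of compound 2 or share the loss of compound 4. Also open, going by these compounds, is how this core responds to a methoxy group or an amine on the ring attached to the sulfur.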